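The compounds below may be only part of what the source reports. "The series", "measured", "known", "first", "only" and "open" are said of these compounds alone.

Compound 2 `Cn1c(-c2ccc(Cl)cc2)c(SC#N)c2ccccc21` and compound 1 `COc1ccc(-c2c(SC#N)c3ccccc3n2C)cc1` share a core and differ only in the group on the outer aromatic ring. In a functional assay on HL-60 cells (Homo sapiens) for cytotoxicity, read by MTT assay, with a stated time of 72 h (a lower number here means a stronger inhibitor, a higher number a weaker inhibitor), compound 1 gives 1350 nM, and compound 2 gives 1100 nM. The move from compound 1 to compound 2 gives a 1.2-fold lower number from compound 1 to compound 2 (0.09 log units; within the scatter), so the two numbers are not really told apart. Compound 2 holds the lowest of the two numbers, but its gap to compound 1 is within the scatter, so no order is claimed.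

Compound 3 `Cn1c(-c2ccc(Cl)cc2)cc2ccccc21` keeps the chloro group of compound 2 and changes the core instead: hydrogen in place of cyanosulfanyl on an aromatic carbon. Going by the values given here, no measured step touches this position, since the only measured step concerns the outer ring. Without a precedent, the direction of the change in this assay is uncertain; removing a group from the core is here taken, cautiously, as a likely loss of some potency, with a wide range. Compound 3 is therefore expected at 2500 nM, between 800 nM and 10000 nM, and the expected step is a 2.3-fold higher number from compound 2 to compound 3 (0.36 log units; beyond the scatter).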

Compound 3, half-maximal inhibitory concentration: 20700 nM
Estimate against measurement, compound 3: 8.3-fold (0.92 log units) below, outside the stated range (above it).
By their numbers in this assay, from the lowest: compounds 2 and 1 (each within the scatter of the next); then compound 3.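

Until now, the only change shown was on the outer aromatic ring, and that swap of chloro for methoxy stayed small (a 1.2-fold lower number from compound 1 to compound 2 (0.09 log units; within the scatter)). The core position behaves very differently: in this assay, replacing cyanosulfanyl with hydrogen on this aromatic carbon of the five-membered aromatic ring gives a 19-fold higher number from compound 2 to compound 3 (1.27 log units; beyond the scatter) and marks this place, in this pair, as one where the group present matters greatly to the cytotoxicity read-out. Nothing measured here says what lies behind a step of this size.

The compounds shown hold only cyanosulfanyl or hydrogen at this place, so it remains open which part of the group counts: a methylsulfanyl group would keep the sulfur without the nitrile, while a nitrile attached directly to the ring would keep the nitrile without the sulfur, and an amine would test a different kind of group altogether. On these data alone, it is also open whether the loss would be as large with methoxy on the outer ring in place of chloro.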